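Methyl on a phenolic oxygen in a small amidine series

The compounds below may be only part of what the source reports. "The series", "measured", "known", "first", "only" and "open" are said of these compounds alone.

Three compounds of one series are measured in a functional assay on SH-SY5Y cells (Homo sapiens) for cytotoxicity, read by MTT assay, with stated times of 8 h, 30 min and 12 h, tested at 5 uM; a lower number here means a weaker effect, a higher number a stronger effect of the compound at the concentration tested. Compound 1 `COc1ccc(CN2C(=O)CC[C@H]2C(=N)NCc2ccc(O)cc2)cc1` gives 26.6%. Compound 2 `COc1ccc(CNC(=N)[C@@H]2CCC(=O)N2Cc2ccc(OC)cc2)cc1` gives 33.6%. Compound 3 `Cc1ccc(CN2C(=O)CC[C@H]2C(=N)NCc2ccc(O)cc2)cc1` gives 23.8%; its nearest neighbour in number is compound 1, its furthest compound 2, both within the scatter, so no order among the three is claimed.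

Compound 3 differs from compound 1 by methyl in place of methoxy on an aromatic carbon. Compound 2 differs from compound 1 by methyl in place of hydrogen on an oxygen on an aromatic ring, and the same change is made from compound 3 to compound 4 `COc1ccc(CNC(=N)[C@@H]2CCC(=O)N2Cc2ccc(C)cc2)cc1`: methyl in place of hydrogen on an oxygen on an aromatic ring, at a place worded the same in both cases.

The measured instance of this change shows a number 7 percentage points higher from compound 1 to compound 2 (within the scatter). The second instance starts from compound 3, whose difference from compound 1 is a number 2.8 percentage points lower from compound 1 to compound 3 (within the scatter), also within the scatter. For the measured compounds named here, only one measured step of this kind exists, and both measured steps lie within the scatter, so the expectation is that the change from compound 3 to compound 4 moves the number by about the same small amount, and the estimated step is a number 7.2 percentage points higher from compound 3 to compound 4 (within the scatter). The estimate rests on compound 2 giving 33.6% after the same change from compound 1 at 26.6%.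

For compound 4 the expected value in this assay is 31%, with a range from 18% to 44% to cover the usual scatter.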

Compound 4, a percentage reported as activity, at one concentration (the size of the read-out at that concentration, not a potency): 29.5%
Estimate against measurement, compound 4: 1.5 percentage points above; measured number inside the range.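

In this assay, the change of hydroxy to methoxy on an aromatic ring now reads a number 5.7 percentage points higher from compound 3 to compound 4 (within the scatter), and set beside the earlier instance it shows no difference between the two cores: the same change on two cores in this assay, a number 7 percentage points higher (within the scatter) from compound 1 to compound 2 and a number 5.7 percentage points higher (within the scatter) from compound 3 to compound 4, 1.3 percentage points apart, within the scatter of two such steps. The change to methyl in place of methoxy on an aromatic carbon, now read as a number 4.1 percentage points lower from compound 2 to compound 4 (within the scatter), likewise agrees with its earlier instance: the same change on two cores in this assay, a number 2.8 percentage points lower (within the scatter) from compound 1 to compound 3 and a number 4.1 percentage points lower (within the scatter) from compound 2 to compound 4, 1.3 percentage points apart, within the scatter of two such steps. For the compounds shown here, all of these steps lie within the scatter, so the agreement shows only that neither change registers on either core; it shows no real effect carried from one core to the other, and two pairs say nothing about further cores.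

Still open, from the compounds shown here alone, is whether any larger step appears with other groups at these places on the aromatic rings, such as an amine, a carboxylic acid, a halogen or a longer chain in place of hydroxy, methoxy or methyl. The read-out is also a size of effect at one concentration, so these four compounds leave open whether the effect of any of them would be stronger or weaker at another concentration, and whether changes that do not register here would do so there.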